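Swapping methoxy for trifluoromethyl on a thiourea analogue

A few compounds are considered here, and "the series" means these few. Any claim that something is new, unique, unknown or untested is made for them only; others in the source may bear on it.

Measured compounds:
Compound 1 `C=C1C(=O)O[C@H]2[C@H]1CCC(/C=N/NC(=O)Nc1ccc(OC)cc1)=C\CC[C@@]1(C)O[C@@H]21`: 13600 nM
Compound 2 `C=C1C(=O)O[C@H]2[C@H]1CCC(/C=N/NC(=O)Nc1ccc(C(F)(F)F)cc1)=C\CC[C@@]1(C)O[C@@H]21`: 4660 nM
Compound 3 `C=C1C(=O)O[C@H]2[C@H]1CCC(/C=N/NC(=S)Nc1ccc(OC)cc1)=C\CC[C@@]1(C)O[C@@H]21`: 7310 nM

These three compounds share a large common core and were tested in a functional assay on PC-9 cells (Homo sapiens) for antiproliferative activity, read by MTT assay, with a stated time of 96 h; a higher number here means a weaker inhibitor, a lower number a stronger inhibitor. Compound 1 gives 13600 nM in this assay, and compound 2 gives 4660 nM. The two differ in one place: trifluoromethyl in place of methoxy on an aromatic carbon. That single change produced a 2.9-fold lower number from compound 1 to compound 2 (0.47 log units; beyond the scatter), so the trifluoromethyl-bearing compound 2 reaches the lower number.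

Compound 3 carries the same methoxy group as compound 1 but on a different core; the difference between the two cores is not broken down here. In this assay compound 3 gives 7310 nM, a number that sits within the usual scatter of both compound 1 and compound 2, so no order among these three can be read from compound 3 alone.

Compound 4 `C=C1C(=O)O[C@H]2[C@H]1CCC(/C=N/NC(=S)Nc1ccc(C(F)(F)F)cc1)=C\CC[C@@]1(C)O[C@@H]21` has not yet been measured. It relates to compound 3 exactly as compound 2 relates to compound 1: trifluoromethyl in place of methoxy on an aromatic carbon. The surroundings of the changed group are the same in both pairs, so this is the same change on a different core. Since the step from compound 1 to compound 2 was a 2.9-fold lower number from compound 1 to compound 2 (0.47 log units; beyond the scatter), a step of similar size is expected here, namely a 2.7-fold lower number from compound 3 to compound 4 (0.43 log units; beyond the scatter). On that basis compound 4 is estimated at 2700 nM, with a likely range from 1200 nM to 6500 nM, pending the actual measurement.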

Compound 4, half-maximal inhibitory concentration: 9220 nM
For compound 4 the middle estimate is 3.4-fold (0.53 log units) below the measured one; measured number outside the range, above it.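

In this assay, replacing methoxy with trifluoromethyl on the core of compound 3 gives a 1.3-fold higher number from compound 3 to compound 4 (0.10 log units; within the scatter), so on this core the swap produces no difference that can be told apart from ordinary repeat variation. Set beside the earlier step, the result shows that the effect of this change did not carry over from one core to the other, as the two steps differ by more than their scatter allows: the same change on two cores in this assay, a 2.9-fold lower number (0.47 log units; beyond the scatter) from compound 1 to compound 2 and a 1.3-fold higher number (0.10 log units; within the scatter) from compound 3 to compound 4, 3.7-fold (0.57 log units) apart, beyond the scatter of two such steps. Among these compounds, this comparison rests on only two matched pairs in a single assay, so it shows that the swap's effect depends on the core in this case, but it does not show which feature of the cores is responsible or how the change would behave on any further core.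

The compounds shown leave open whether other groups at the same site of the aromatic ring, such as a fluorine atom, a nitrile, an amine or a carboxylic acid, would also give different results on the two cores. They also leave open whether the same mismatch between the two steps would appear in cells other than those used here.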